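Amide substituents on the shared core: ethyl to isopropyl

The source may hold more compounds than are shown below. What is called first, only, known or untested is meant among the compounds shown, and "the series" means these compounds.

Values in an ADME assay on PBMC cells (Homo sapiens) for cytotoxicity, read by MTT assay, with a stated time of 48 h (a lower number here means a stronger inhibitor, a higher number a weaker inhibitor), each one a limit and not a number:
- compound 1 `NC(=O)CC[C@H](NS(=O)(=O)c1ccc([N+](=O)[O-])cc1)C(=O)O`: > 1000000 nM
- compound 2 `CNC(=O)CC[C@H](NS(=O)(=O)c1ccc([N+](=O)[O-])cc1)C(=O)O`: > 1000000 nM
- compound 3 `CCNC(=O)CC[C@H](NS(=O)(=O)c1ccc([N+](=O)[O-])cc1)C(=O)O`: > 1000000 nM

Compound 3 has only a limit, > 1000000 nM. The series offers no number to rank it against, with the limit of > 1000000 nM in this assay, at which 3 of the 3 values shown sit.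

Compound 4 `CC(C)NC(=O)CC[C@H](NS(=O)(=O)c1ccc([N+](=O)[O-])cc1)C(=O)O` is the next to be read. The structural difference is methyl in place of hydrogen on a saturated chain carbon bound to an amide-type nitrogen and a saturated chain carbon. In other words, ethylcarbamoyl becomes isopropylcarbamoyl.

The closest measured step is a step that the two limits leave unreadable from compound 2 to compound 3, which is also methyl in place of hydrogen on a saturated chain carbon bound to an amide-type nitrogen. The steps a step that the two limits leave unreadable from compound 1 to compound 2 and a step that the two limits leave unreadable from compound 1 to compound 3 change the same amide-type nitrogen. None of the three has a readable size, and none gives a direction. No step beyond the scatter is therefore expected in this assay, and a further reading at the limit is likely. The expected change is a step that the limit leaves unreadable from compound 3 to compound 4. The estimate for compound 4 is 1500000 nM, with an expected range of 700000 nM to 3500000 nM.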

Compound 4, half-maximal inhibitory concentration: > 1000000 nM
Compound 4 gave a limit, no number; the forecaster's own chance of this, stated with the estimate: 90%; the middle value does not contradict the limit.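

In this assay compound 4 gives > 1000000 nM, a limit and not a number, so no step among compounds 1, 2, 3 and 4 can be read: the limit of > 1000000 nM in this assay, at which 4 of the 4 values shown sit.

The compounds shown leave open whether any amide substituent on the shared core gives a measurable value in this assay.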